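The compounds below may be only part of what the source reports. "The series", "measured", "known", "first", "only" and "open" are said of these compounds alone.

Compound 1 `CC(=O)OCCc1c(C)nc(Cl)nc1Cl` and compound 3 `Cc1nc(Cl)nc(Cl)c1CCCl` share one core; compound 2 `COc1nc(C)c(CCOC(C)=O)c(OC)n1` and the still unmeasured compound 4 `COc1nc(C)c(CCCl)c(OC)n1` share another, and the difference between the two cores is not broken down here. In a functional assay on HCT-116 cells (Homo sapiens) for antiproliferative activity, read by MTT assay, with a stated time of 24 h (on this read-out higher numbers stand for weaker inhibition and lower numbers for stronger inhibition), compound 1 gives > 100000 nM, which is a limit and not a number, namely (the limit of > 100000 nM in this assay, at which 1 of the 3 values shown sits). In this assay compound 3 gives 2000 nM and compound 2 gives 40000 nM. The change made from compound 1 to compound 3 is chloro in place of acetoxy on a saturated chain carbon, two bonds along the chain from an aromatic carbon and it produced an at least 50-fold lower number from compound 1 to compound 3 (1.69 log units; beyond the scatter). The same change on the other core, (chloro in place of acetoxy on a saturated chain carbon, two bonds along the chain from an aromatic carbon), leads to compound 4. Since the earlier step started at a limit, only its lower bound is known; for compound 4 the step is expected to be a 40-fold lower number from compound 2 to compound 4 (1.60 log units; beyond the scatter). Compound 4 is therefore estimated at 1000 nM, between 200 nM and 6000 nM.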

Compound 4, half-maximal inhibitory concentration: > 100000 nM
Compound 4: a limit, no number; the forecaster's own chance of this, stated with the estimate: 5%; at least 100-fold (2.00 log units) between middle value and limit.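

In this assay the change to chloro in place of acetoxy gives an at least 2.5-fold higher number from compound 2 to compound 4 (0.39 log units; beyond the scatter), the opposite direction to the step on the core of compound 1. The change therefore does not carry over from one core to the other in this pair of steps: the same change on two cores in this assay, an at least 50-fold lower number (1.69 log units; beyond the scatter) from compound 1 to compound 3 and an at least 2.5-fold higher number (0.39 log units; beyond the scatter) from compound 2 to compound 4, at least 120-fold (2.09 log units) apart, beyond the scatter of two such steps
Compound 4 gives > 100000 nM, which is a limit and not a number, so the step has a lower bound only, and the two steps show that the outcome differs by core, not why it differs: the limit of > 100000 nM in this assay, at which 2 of the 4 values shown sit.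

From the compounds shown here alone, it remains open which feature of the two cores decides the outcome. Going by these compounds, it also remains open how an amine, a hydroxy group or a longer chain in place of acetoxy would read on each core.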